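The source may report more compounds than this note shows. Statements on the series, on what has been measured and on what is new or still open speak of the compounds shown alone.

Measured compounds in a functional assay on the whole organism (strain Wistar) for inhibition, with Rattus norvegicus as the target, read by paw edema, with stated times of 60 min and 6 h, at a dose of 100 mg/kg by the oral route; on this read-out higher numbers stand for more inhibition at the one dose given (going by the name of the read-out) and lower numbers for less inhibition:
- compound 1 `COc1cc2c(cc1OC)C(CC(N)=O)CC2`: 27.8%
- compound 2 `CCN(CC)C(=O)CC1CCc2cc(OC)c(OC)cc21`: 31.5%
- compound 3 `COc1cc2c(cc1OC)C(CC(=O)NCc1ccccc1)CC2`: 30.6%

Compound 1 has the lowest of these three numbers, but its distance to each of the others lies within the scatter, so the three stand together. The step to compound 4 `COc1cc2c(cc1OC)C(CC(=O)N1CCCC1)CC2` is this change: pyrrolidin-1-yl in place of amino on a carbonyl carbon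

The closest measured steps also replace the amino group on that carbonyl carbon. Going from compound 1 to compound 2 in this assay gave a number 3.7 percentage points higher from compound 1 to compound 2 (within the scatter), and from compound 1 to compound 3 gave a number 2.8 percentage points higher from compound 1 to compound 3 (within the scatter); between those two, a number 0.9 percentage points lower from compound 2 to compound 3 (within the scatter). All three steps lie within the scatter, so no move beyond the scatter is expected here either, and compound 4 is expected to land at about 31%, in the range 22% to 40%, which means an estimated step of a number 3.2 percentage points higher from compound 1 to compound 4 (within the scatter).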

Compound 4, a percentage reported as inhibition, in the whole organism at one dose (the size of the read-out at that dose, not a potency): 22.2%
Compound 4: middle estimate off by 8.8 percentage points, on the high side; the range from low to high includes it.
By their numbers in this assay, from the lowest: compounds 4, 1, 3 and 2 (each within the scatter of the next).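

In this assay, a ring on this carbonyl carbon gives a number 5.6 percentage points lower from compound 1 to compound 4 (within the scatter), along with a number 8.4 percentage points lower from compound 3 to compound 4 (within the scatter) and a number 9.3 percentage points lower from compound 2 to compound 4 (within the scatter). A pyrrolidin-1-yl ring in place of the amino group therefore joins the open-chain diethylamino and benzylamino groups in causing no step beyond the scatter. No measurement here offers an explanation for these numbers. Still open, going by these compounds, is what a carboxylic acid or a morpholin-4-yl group would give at this carbonyl carbon, and whether any replacement there can move the read-out beyond the scatter.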